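Acetyl for Phenyl in a Cytotoxicity Series

The source may hold more compounds than are shown below. What is called first, only, known or untested is meant among the compounds shown, and "the series" means these compounds.

Compound 1: `Cc1c(-c2csc(NC(=S)Nc3ccccc3)n2)c(=O)n(-c2ccccc2)n1C` — 8350 nM
Compound 2: `Cc1c(-c2csc(/N=c3\sc(-c4ccccc4)nn3-c3ccccc3)n2)c(=O)n(-c2ccccc2)n1C` — > 100000 nM

In a functional assay on HepG2 cells (Homo sapiens) for cytotoxicity, read by sulforhodamine B assay, with a stated time of 72 h (on this read-out higher numbers stand for weaker inhibition and lower numbers for stronger inhibition), compound 1 gives 8350 nM. Compound 2 gives only a limit of the assay, > 100000 nM, so no number is known for it. Compound 2 stands at the limit of > 100000 nM in this assay, at which 1 of the 2 values shown sits. Compound 3, `CC(=O)c1nn(-c2ccccc2)/c(=N/c2nc(-c3c(C)n(C)n(-c4ccccc4)c3=O)cs2)s1`, differs from compound 2 by acetyl in place of phenyl on an aromatic carbon. For the measured compounds named here, no measured pair shows a change of this kind, so no direction can be read from the data, and the value is expected to stay near the limit. Compound 3 is therefore estimated at 70000 nM, within 15000 nM to 300000 nM. The expected step of an at least 1.4-fold lower number from compound 2 to compound 3 (0.15 log units; that floor lies within the scatter) is small.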

Compound 3, half-maximal inhibitory concentration: 67100 nM
Compound 3: the middle estimate sits 1.0-fold (0.02 log units) above what was measured, within the range that was stated.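

In this assay, acetyl in place of phenyl on this aromatic carbon gives an at least 1.4-fold lower number from compound 2 to compound 3 (0.17 log units; that floor lies within the scatter). Compound 3 thus gives this position its first real number, 67100 nM. Going by these compounds, the true size of the step stays unknown, and what compound 2 offers is only a limit: the limit of > 100000 nM in this assay, at which 1 of the 3 values shown sits.

The compounds shown leave open what an amine or a carboxylic acid on this carbon would give. They also leave open whether any change follows the loss of the phenyl ring or the arrival of the acetyl carbonyl.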